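A few compounds are considered here, and "the series" means these few. Any claim that something is new, unique, unknown or untested is made for them only; others in the source may bear on it.

Going by the values given here, only two compounds have numbers so far in an ADME assay on L02 cells (Homo sapiens) for cytotoxicity, read by MTT assay, with a stated time of 48 h; a lower number here means a stronger inhibitor, a higher number a weaker inhibitor. Compound 1, `CCn1c(C(=O)NCC(OC)OC)ccc1C(CC)(CC)c1ccc(OCC(O)C(C)(C)C)c(C)c1`, gives 22200 nM, the higher of the two numbers. Compound 2, `CCn1c(C(=O)N(C)CC(=O)O)ccc1C(CC)(CC)c1ccc(OCC(=O)C(C)(C)C)c(C)c1`, gives 8700 nM, so compound 1 is the weaker inhibitor of the pair, by a gap beyond the usual scatter. Compound 3, `CCn1c(C(=O)Oc2ccc(CCO)cc2)ccc1C(CC)(CC)c1ccc(OCC(O)C(C)(C)C)c(C)c1`, has yet to be measured in this assay. It departs from compound 1 at one place, on a carbonyl carbon whose other neighbours are aromatic carbon: a group of 10 heavy atoms (8 carbon, 2 oxygen; one six-membered aromatic ring of carbon only) in place of a group of 7 heavy atoms (4 carbon, 1 nitrogen, 2 oxygen; no ring), on a carbonyl carbon. The (2,2-dimethoxyethyl)amino group leaves, and a group with a six-membered aromatic ring of carbon only enters. Among the compounds with values here, no two measured compounds differ in just one place, so no measured step guides this change. The expectation therefore rests on the two values alone, and it is a loose one: a small move towards a lower number, not clearly beyond the scatter. The expected change is a 1.5-fold lower number from compound 1 to compound 3 (0.17 log units; within the scatter). Compound 3 is estimated at 15000 nM, with an expected range of 6000 nM to 40000 nM.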

Compound 3, half-maximal inhibitory concentration: 22700 nM
Compound 3: middle estimate off by 1.5-fold (0.18 log units), on the low side; low and high end bracket the measured number.
By their numbers in this assay, from the lowest: compound 2; then compounds 1 and 3 (each within the scatter of the next).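

In this assay, the carbonyl carbon now has its first measured step: replacing the (2,2-dimethoxyethyl)amino group with the larger group bearing a six-membered aromatic ring of carbon only gives a 1.0-fold higher number from compound 1 to compound 3 (0.01 log units; within the scatter), which leaves compound 1 and compound 3 indistinguishable in this read-out. This one swap adds a ring and more heavy atoms and removes the nitrogen, while the two groups match in hydrogen-bond donors and acceptors and neither carries a net charge, so this pair shows that these structural differences together need not move the number beyond the scatter. Nothing available accounts for this result.

Since the ring and the loss of the nitrogen arrive together in compound 3, the compounds shown leave their separate contributions unresolved. They also leave open how the number would respond to quite different groups on this carbonyl carbon, such as a piperidine ring or a morpholine ring, and whether any such group would give a step beyond the scatter.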